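Swapping chloro for trifluoromethyl on a weak cytotoxic series

The source may report more compounds than this note shows. Statements on the series, on what has been measured and on what is new or still open speak of the compounds shown alone.

Four close relatives of one shared core are compared in a functional assay on KB cells (Homo sapiens) for cytotoxicity, read by MTT assay, with a stated time of 72 h; a higher number here means a weaker inhibitor, a lower number a stronger inhibitor. Compound 1 `Cc1ccc(S(=O)(=O)c2nc3ccccc3nc2Nc2ccc(Cl)cc2)cc1` is the reference; in this assay compound 1 gives 13800 nM. Compound 2 `Cc1ccc(S(=O)(=O)c2nc3ccccc3nc2Nc2ccc(C(F)(F)F)cc2)cc1` differs from compound 1 by trifluoromethyl in place of chloro on an aromatic carbon. In this assay compound 2 gives 10300 nM, and the step is a 1.3-fold lower number from compound 1 to compound 2 (0.13 log units; within the scatter). Compound 3 `COc1ccc(S(=O)(=O)c2nc3ccccc3nc2Nc2ccc(Cl)cc2)cc1` differs from compound 1 on the other side of the core by methoxy in place of methyl on an aromatic carbon. In this assay compound 3 gives 49800 nM, and the step is a 3.6-fold higher number from compound 1 to compound 3 (0.56 log units; beyond the scatter), so compound 3 sits at the high end of the three measured values.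

Compound 4 `COc1ccc(S(=O)(=O)c2nc3ccccc3nc2Nc2ccc(C(F)(F)F)cc2)cc1` has not yet been measured. Among the compounds with values here, it differs from compound 3 by trifluoromethyl in place of chloro on an aromatic carbon, which is the same change as the one from compound 1 to compound 2, at the same place. Within the data shown here, only that single earlier example of the change exists here, so the expectation rests on one step alone. Because the earlier step was a 1.3-fold lower number from compound 1 to compound 2 (0.13 log units; within the scatter), the step from compound 3 to compound 4 is expected to be similar, about a 1.3-fold lower number from compound 3 to compound 4 (0.12 log units; within the scatter). Compound 4 is therefore expected to give around 38000 nM in this assay. Given the usual spread of such measurements, the value for compound 4 is estimated to fall between 15000 nM and 100000 nM.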

Compound 4, half-maximal inhibitory concentration: 890 nM
Compound 4: middle estimate off by 43-fold (1.63 log units), on the high side; the whole stated range lies above it.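

In this assay, trifluoromethyl in place of chloro gives a 56-fold lower number from compound 3 to compound 4 (1.75 log units; beyond the scatter) on the core carrying methoxy, whereas the same swap on the core carrying methyl stayed within the scatter: the same change on two cores in this assay, a 1.3-fold lower number (0.13 log units; within the scatter) from compound 1 to compound 2 and a 56-fold lower number (1.75 log units; beyond the scatter) from compound 3 to compound 4, 42-fold (1.62 log units) apart, beyond the scatter of two such steps

Read the other way round, methoxy in place of methyl gives a 12-fold lower number from compound 2 to compound 4 (1.06 log units; beyond the scatter) when trifluoromethyl is present, which runs opposite to the step seen when chloro is present: the same change on two cores in this assay, a 3.6-fold higher number (0.56 log units; beyond the scatter) from compound 1 to compound 3 and a 12-fold lower number (1.06 log units; beyond the scatter) from compound 2 to compound 4, 42-fold (1.62 log units) apart, beyond the scatter of two such steps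

Within the data shown here, neither change can therefore be carried from one core to another as a fixed step, since the effect of each depends on the group on the other side; however, these two comparisons are one finding seen from two sides, resting on the same four compounds and leaning heavily on the single value of compound 4, and they do not show why the two groups work together in this way.

The compounds shown leave open whether this large gain is particular to methoxy or would also appear with an ethoxy group or a dimethylamino group in its place. They also leave open whether a nitrile or a bromine atom in place of trifluoromethyl would behave like trifluoromethyl or like chloro.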